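Aryl swap on the piperazine nitrogen: compound 3 to compound 4

The source may report more compounds than this note shows. Statements on the series, on what has been measured and on what is new or still open speak of the compounds shown alone.

Compound 3 `COC(=O)C1=C(C)NC(=O)N(C(=O)NCCCN2CCN(c3ccc(Cl)cc3)CC2)C1c1ccc(F)c(F)c1` sits second highest of the three numbers in an assay on liver for binding affinity to Alpha-1A adrenergic receptor (Homo sapiens), using microsomes (on this read-out lower numbers stand for stronger inhibition and higher numbers for weaker inhibition), where compound 3 gives 0.8 nM. Compound 1 `COC(=O)C1=C(C)NC(=O)N(C(=O)NCCCN2CCN(c3ccccc3O)CC2)C1c1ccc(F)c(F)c1` gives 0.6 nM and compound 2 `CCC1=C(C(N)=O)C(c2ccc(F)cc2F)N(C(=O)NCCCN2CCN(c3ccccc3C(N)=O)CC2)C(=O)N1` gives 1.3 nM, both within the scatter of compound 3. Compound 4 `COC(=O)C1=C(C)NC(=O)N(C(=O)NCCCN2CCN(c3cccc([N+](=O)[O-])c3)CC2)C1c1ccc(F)c(F)c1` differs from compound 3 by 3-nitrophenyl in place of 4-chlorophenyl on an amine nitrogen in a ring. Going by the values given here, the one measured step at the same place, a 1.3-fold higher number from compound 1 to compound 3 (0.12 log units; within the scatter), stayed within the scatter, so the aryl group on this ring nitrogen has so far moved this assay little. Among the compounds with values here, no step bearing on a nitro group exists. The expected step in this assay is therefore none beyond the scatter, a 1.3-fold higher number from compound 3 to compound 4 (0.10 log units; within the scatter). Compound 4 is estimated at 1 nM, with a range of 0.4 nM to 2.5 nM.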

Compound 4, inhibition constant: 12 nM
The estimate for compound 4 lay 12-fold (1.08 log units) below the measured number; measured number above the stated range.
By their numbers in this assay, from the lowest: compounds 1, 3 and 2 (each within the scatter of the next, the first and the last beyond it); then compound 4.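

In this assay the aryl group on this ring nitrogen is not free to vary: 3-nitrophenyl brings a 15-fold higher number from compound 3 to compound 4 (1.18 log units; beyond the scatter) and a 20-fold higher number from compound 1 to compound 4 (1.30 log units; beyond the scatter) on the shared core. The earlier swap of 2-hydroxyphenyl for 4-chlorophenyl stayed within the scatter, so this position accepts some of the aryl groups shown but not all of them.

As far as these compounds go, whether the rise follows the nitro group itself or its place on the phenyl ring stays open, as does how an amine or a nitrile would read in its stead. No measurement at hand explains the step.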